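Series notes: aryl to benzyl swap on the pyrrole nitrogen

The source may report more compounds than this note shows. Statements on the series, on what has been measured and on what is new or still open speak of the compounds shown alone.

Going by the values given here, compound 2 `CC/N=C1\S/C(=C\c2cc(C)n(-c3ccc(F)cc3F)c2C)C(=O)N1CC` gives 6180 nM in a functional assay for agonist activity at sphingosine 1-phosphate receptor 5 (Homo sapiens) (a lower number here means that less compound is needed, a higher number that more compound is needed for the effect), the highest of the two numbers so far; compound 1 `CC/N=C1\S/C(=C\c2cc(C)n(-c3ccccc3)c2C)C(=O)N1CC` gives 237 nM. Among the compounds with values here, the step of a 26-fold higher number from compound 1 to compound 2 (1.42 log units; beyond the scatter) is the only measured step and bears on compound 3 `CC/N=C1\S/C(=C\c2cc(C)n(Cc3c(F)cccc3F)c2C)C(=O)N1CC` only loosely, since compound 3 differs from compound 2 by 2,6-difluorobenzyl in place of 2,4-difluorophenyl on an aromatic nitrogen. Within the data shown here, no measured step covers a benzyl group on that nitrogen, so direction is uncertain. Compound 3 is expected to give about 2500 nM in this assay, a step of a 2.5-fold lower number from compound 2 to compound 3 (0.39 log units; beyond the scatter), with an estimated range from 300 nM to 20000 nM.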

Compound 3, half-maximal effective concentration: 22 nM
For compound 3 the middle estimate is 110-fold (2.06 log units) above the measured one; measured number outside the range, below it.
By their numbers in this assay, from the lowest: compound 3; then compound 1; then compound 2.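

At this position on the aromatic nitrogen, this assay accepts more than a directly attached aryl ring: 2,6-difluorobenzyl gives a 280-fold lower number from compound 2 to compound 3 (2.45 log units; beyond the scatter). The same group also gives an 11-fold lower number from compound 1 to compound 3 (1.03 log units; beyond the scatter), so the number can fall well under that of the plain phenyl compound, and two fluorines on the ring do not raise it in every setting. Nothing at hand explains the size of these steps.

The change alters both the attachment and the fluorine placement, so their shares stay unresolved. Open too, on these data alone, is how unsubstituted benzyl, 2,4-difluorobenzyl or a longer phenethyl chain would read here.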